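Ring size and ring hetero atom at the ether carbon

This account rests on a few compounds, and the source may have more. Where it says the series, first, only, none or still open, it means among the compounds named here.

compound 1 `Nc1ccc2cccc(OCC3CCCC3)c2n1`: 53 nM
compound 2 `CCCCCOc1cccc2ccc(N)nc12`: 580 nM
compound 3 `Nc1ccc2cccc(OCC3CC3)c2n1`: > 2000 nM

In an assay on cells with melanin-concentrating hormone receptor 1 (Homo sapiens) as the target, read by radioligand binding (a higher number here means a weaker inhibitor, a lower number a stronger inhibitor), compound 1 gives the lowest of the two plain numbers, with compound 2 the nearest at an 11-fold higher number from compound 1 to compound 2 (1.04 log units; beyond the scatter). For compound 3 the value is a limit of the assay, (the limit of > 2000 nM in this assay, at which 1 of the 3 values shown sits).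

Compound 4 `Nc1ccc2cccc(OCC3CCOC3)c2n1` differs from compound 1 as follows: oxolan-3-yl in place of cyclopentyl on a saturated chain carbon bound to an oxygen on an aromatic ring. The steps measured at the same place are an 11-fold higher number from compound 1 to compound 2 (1.04 log units; beyond the scatter), an at least 37-fold higher number from compound 1 to compound 3 (1.57 log units; beyond the scatter) and an at least 3.4-fold higher number from compound 2 to compound 3 (0.53 log units; beyond the scatter); every departure from cyclopentyl raised the number, the five-membered ring being the best of the three. The oxolan-3-yl ring keeps that size but carries a hetero atom, so a weakening of modest size is expected, a 3.8-fold higher number from compound 1 to compound 4 (0.58 log units; beyond the scatter). Compound 4 is estimated at 200 nM, within 60 nM to 800 nM.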

Compound 4, half-maximal inhibitory concentration: 115 nM
Compound 4: middle estimate off by 1.7-fold (0.24 log units), on the high side; measured number inside the range.
By their numbers in this assay, from the lowest: compound 1; then compound 4; then compound 2. At a limit, above all of these: compound 3.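

In this assay, the ring oxygen of oxolan-3-yl carries only a modest penalty at this place: a 2.2-fold higher number from compound 1 to compound 4 (0.34 log units; beyond the scatter). The five-membered ring thus holds up with a hetero atom in it, and it still outdoes the open chain, with a 5.0-fold lower number from compound 2 to compound 4 (0.70 log units; beyond the scatter). Compound 3 stands at a limit of the assay, so an at least 17-fold lower number from compound 3 to compound 4 (1.24 log units; beyond the scatter) is a bound only: the limit of > 2000 nM in this assay, at which 1 of the 4 values shown sits.

Still open is how a cyclohexyl ring would read at this place, where the ring-size series shown stops at five members. Also open, on these data alone, is whether a ring nitrogen, as in a pyrrolidine, would behave like the oxygen of compound 4.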